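The source may report more compounds than this note shows. Statements on the series, on what has been measured and on what is new or still open speak of the compounds shown alone.

Measured compounds in an assay on CHO cells for displacement of a labelled ligand from 5-hydroxytryptamine receptor 1D (Homo sapiens); a higher number here means a weaker inhibitor, a lower number a stronger inhibitor:

compound 1 `O=S(=O)(NCC1CCN(CCCc2c[nH]c3ccc(-n4cnnc4)cc23)CC1)c1ccccc1`: 6.2 nM
compound 2 `c1ccc(CNC2CCN(CCCc3c[nH]c4ccc(-n5cnnc5)cc34)CC2)cc1`: 4.6 nM
compound 3 `c1ccc(C2CCCCN2C2CCN(CCCc3c[nH]c4ccc(-n5cnnc5)cc34)CC2)cc1`: 1.9 nM

Compound 2 sits in the middle of the three numbers. Its nearest neighbour is compound 1, and the step of a 1.3-fold lower number from compound 1 to compound 2 (0.13 log units; within the scatter) keeps the two within the scatter, so no order between them is claimed. Compound 3 gives 1.9 nM, a lower number than compound 2 by a margin beyond the scatter.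

Compound 4 `CC(=O)Nc1ccc(CNC2CCN(CCCc3c[nH]c4ccc(-n5cnnc5)cc34)CC2)cc1` differs from compound 2 in one place:

acetamido in place of hydrogen on an aromatic carbon

Within the data shown here, no measured step bears directly on this change. Among the measured compounds shown here, the only step in the set, a 1.3-fold lower number from compound 1 to compound 2 (0.13 log units; within the scatter), exchanges one whole group on a saturated ring carbon for another and lies within the scatter; it says nothing about a substituent added to the phenyl ring of the benzyl group. The gap from compound 2 to compound 3 concerns a different part of the molecule and is not a single-point comparison. With nothing to go on beyond the size of the series, the expectation for compound 4 in this assay is a step of no clear direction, most likely within the scatter, with wider uncertainty than a repeated measurement would carry.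

Compound 4 is therefore estimated at 5 nM, in the range 2 nM to 15 nM.

The expected step of a 1.1-fold higher number from compound 2 to compound 4 (0.04 log units; within the scatter) amounts to no change beyond the scatter.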

Compound 4, half-maximal inhibitory concentration: 3 nM
Beside the measured number, compound 4's estimate is 1.7-fold (0.22 log units) above it; the range from low to high includes it.
By their numbers in this assay, from the lowest: compounds 3, 4, 2 and 1 (each within the scatter of the next, the first and the last beyond it).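

In this assay, among these compounds, the step of a 1.5-fold lower number from compound 2 to compound 4 (0.19 log units; within the scatter) gives the first reading on the phenyl ring of the benzyl group, since the earlier compounds varied only the group on the saturated ring carbon. Going from phenyl to 4-acetamidophenyl adds 4 heavy atoms, including a hydrogen-bond donor and acceptor, on an aromatic carbon para to a large group, yet the change cannot be told from the scatter, so this place admits at least this one substituent without a measurable loss or gain in this assay. No measured data on any property of these compounds bear on this result, so the absence of a clear effect stays unexplained.

As far as these compounds go, it remains open whether this holds for other groups at the same carbon, such as an amine, a carboxylic acid, a methoxy group or a longer acyl chain, and whether any of them would move the number beyond the scatter in either direction. Also open, from the compounds shown here alone, is whether acetamido on another carbon of the phenyl ring, or on the phenyl ring of a different side group, would read the same.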